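A few compounds are considered here, and "the series" means these few. Any claim that something is new, unique, unknown or untested is made for them only; others in the source may bear on it.

Measured so far:
Compound 1, `CC(C)(C)Oc1ccc2nc(N)sc2c1` — in a functional assay on the whole organism with Rattus norvegicus as the target (on this read-out lower numbers stand for an effect already at smaller amounts and higher numbers for an effect only at larger amounts of compound), compound 1 gives only a limit, > 10 mg/kg.
Compound 2, `Nc1nc2ccc(OCC(F)(F)F)cc2s1` — in this assay compound 2 gives 6.5 mg/kg.

Among the compounds with values here, compound 2 thus holds the only actual number in this assay; the other value shown is a limit, not a number. Within the data shown here, the single measured step runs an at least 1.5-fold lower number from compound 1 to compound 2 (0.18 log units; that floor lies within the scatter), and its size can only be given as a floor because the limit of > 10 mg/kg in this assay, at which 1 of the 2 values shown sits, is all that compound 1 yields.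

Compound 3, `Nc1nc2ccc(OCC(F)(F)C(F)(F)F)cc2s1`, is not yet measured. It differs from compound 2 by trifluoromethyl in place of fluoro on a saturated chain carbon bound to two fluorine atoms and a saturated chain carbon. Among the measured compounds shown here, the one measured step concerns a different exchange, tert-butyl against 2,2,2-trifluoroethyl on an oxygen on an aromatic ring, and its floor lies within the scatter, so it gives no firm direction for lengthening the fluorinated chain. For the measured compounds named here, no other step in this assay bears on this change.

With so little to go on, compound 3 is expected to land close to compound 2 in this assay, at an estimated 5.5 mg/kg, within 2 mg/kg to 15 mg/kg. For compound 3 this amounts to an expected 1.2-fold lower number from compound 2 to compound 3 (0.07 log units; within the scatter), a change not beyond the scatter.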

Compound 3, dose for half-maximal effect: 7.5 mg/kg
For compound 3 the middle estimate is 1.4-fold (0.13 log units) below the measured one; measured number inside the range.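

Putting trifluoromethyl in place of fluoro on a saturated chain carbon bound to two fluorine atoms and a saturated chain carbon gives a 1.2-fold higher number from compound 2 to compound 3 (0.06 log units; within the scatter) in this assay, so this read-out cannot tell compound 2 and compound 3 apart. Within the data shown here, the change brings in four heavy atoms where one left, and the dose for half-maximal effect in the rat stays within the usual scatter, which makes this the first step with a firm size at this place on the chain; the earlier step concerned a different exchange on the oxygen, and its size was only a floor. Nothing measured here explains why this change leaves the read-out within the scatter, and the result alone supplies no reason.

Going by these compounds, it remains open whether this tolerance extends beyond fluorinated groups, for example to an amine or a carboxylic acid at the end of the chain, or to a still longer chain. Compound 1 still offers only a limit, not a number, so its distance from the other two compounds stays unsettled: the limit of > 10 mg/kg in this assay, at which 1 of the 3 values shown sits.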